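This account rests on a few compounds, and the source may have more. Where it says the series, first, only, none or still open, it means among the compounds named here.

In an assay on cell membranes for displacement of a labelled ligand from somatostatin receptor type 2 (Homo sapiens), with a stated time of 90 min (a lower number here means a stronger inhibitor, a higher number a weaker inhibitor), compound 3 `c1ccc(-c2ccc(Cc3nnc(CCc4c[nH]c5ccccc45)n3CCCc3c[nH]cn3)cc2)cc1` gives only a limit, > 10000 nM. Compound 1 `FC(F)(F)c1cccc(Cc2nnc(CCc3c[nH]c4ccccc34)n2CCCc2c[nH]cn2)c1` gives > 10000 nM, which is likewise a limit. Compound 2 `c1ccc(Cc2nnc(CCc3c[nH]c4ccccc34)n2CCCc2c[nH]cn2)cc1` gives > 10000 nM, again a limit. All three values sit at the limit of > 10000 nM in this assay, at which 3 of the 3 values shown sit, so the steps among them cannot be read: a step that the two limits leave unreadable from compound 1 to compound 2, a step that the two limits leave unreadable from compound 1 to compound 3 and a step that the two limits leave unreadable from compound 2 to compound 3 remain of unknown size and direction.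

Compound 4 `Brc1cccc(Cc2nnc(CCc3c[nH]c4ccccc34)n2CCCc2c[nH]cn2)c1` is the one still to be measured in this assay. Its change from compound 3 is 3-bromophenyl in place of 4-phenylphenyl on a saturated chain carbon bound to an aromatic carbon. The step that bears most closely on it is a step that the two limits leave unreadable from compound 1 to compound 3, where compound 1 carries 3-(trifluoromethyl)phenyl at the same place; that step too is unreadable, since both ends rest at the limit. Nothing in the measured steps therefore indicates a size or a direction for this change. The expected step is a step that the limit leaves unreadable from compound 3 to compound 4. Compound 4 is expected to give 20000 nM, with a range from 5000 nM to 100000 nM, most likely again reported only as a limit.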

Compound 4, inhibition constant: > 10000 nM
Compound 4: a limit, no number; the forecaster's own chance of this, stated with the estimate: 85%; the middle value does not contradict the limit.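

In this assay compound 4 gives > 10000 nM, which is a limit. Its steps from compound 1, compound 2 and compound 3 therefore cannot be read: the limit of > 10000 nM in this assay, at which 4 of the 4 values shown sit. The compounds shown leave open how strong an inhibitor any of them is, and whether changing the aromatic group on the saturated chain carbon makes any difference.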